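Removing a Methyl Beside the Bromine on an Amide Chain

The source may report more compounds than this note shows. Statements on the series, on what has been measured and on what is new or still open speak of the compounds shown alone.

Compound 1 `COc1ccc(C(=O)NC(N)=O)cc1NC(=O)C(C)Br` gives > 20000 nM in a functional assay on CCRF-CEM cells (Homo sapiens) for antiproliferative activity, read by trypan blue exclusion, with a stated time of 72 h; a higher number here means a weaker inhibitor, a lower number a stronger inhibitor; this value is a limit of the assay, not a number (the limit of > 20000 nM in this assay, at which 1 of the 3 values shown sits).
Compound 3 `COc1ccc(C(=O)NC(N)=O)cc1NC(=O)CBr` gives 1880 nM in this assay.
Compound 2 `COC(=O)c1cc(NC(=O)C(C)Br)cc(C(=O)NC(N)=O)c1` gives 2700 nM in this assay.

Compound 3 shares its core with compound 1 and differs from it in one place only: hydrogen in place of methyl on a saturated chain carbon bound to a bromine atom and a carbonyl carbon. This change gives an at least 10-fold lower number from compound 1 to compound 3 (1.02 log units; beyond the scatter). Since the starting value is a limit, the true size of that step is known only as a lower bound.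

Compound 2 carries a different core; the difference between the two cores is not broken down here. Its value in this assay lies close to that of compound 3, within the scatter, so the two are not told apart.

Compound 4 `COC(=O)c1cc(NC(=O)CBr)cc(C(=O)NC(N)=O)c1` has not yet been measured. It differs from compound 2 by hydrogen in place of methyl on a saturated chain carbon bound to a bromine atom and a carbonyl carbon, which is the same change, at the same place, as that from compound 1 to compound 3. From compound 2 to compound 4 the step is therefore expected to be about a 6.8-fold lower number from compound 2 to compound 4 (0.83 log units; beyond the scatter). This expectation rests on the large measured step of an at least 10-fold lower number from compound 1 to compound 3 (1.02 log units; beyond the scatter), tempered by the fact that this change has been seen only once and on a different core. Compound 4 is estimated at 400 nM, with a likely span from 100 nM to 1500 nM.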

Compound 4, half-maximal inhibitory concentration: 1300 nM
Compound 4: the middle estimate sits 3.3-fold (0.51 log units) below what was measured, and the stated range covers the measured number.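

Replacing the methyl with hydrogen on the core of compound 2 again lowers the number in this assay, with a 2.1-fold lower number from compound 2 to compound 4 (0.32 log units; beyond the scatter), so the direction of the change carries over to this second core, but its size does not: the same change on two cores in this assay, an at least 10-fold lower number (1.02 log units; beyond the scatter) from compound 1 to compound 3 and a 2.1-fold lower number (0.32 log units; beyond the scatter) from compound 2 to compound 4, at least 5.1-fold (0.70 log units) apart, beyond the scatter of two such steps. The step on the core of compound 1 is known only as a lower bound, and compound 1 itself stands at a limit of the assay, not at a number: the limit of > 20000 nM in this assay, at which 1 of the 4 values shown sits. These two pairs show that the same small edit can give steps of clearly different size on different cores, but they do not show which feature of the cores sets that size, or how large the step would be on a third core.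

The compounds shown leave open whether a longer chain in place of the methyl, or a chlorine atom in place of the bromine atom, would follow the same direction on both cores. They also leave open how the step would change with a carboxylic acid or an amine elsewhere on the core.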